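This account rests on a few compounds, and the source may have more. Where it says the series, first, only, none or still open, it means among the compounds named here.

Compound 1 `CCC1(CCCCN2CCN(c3ccc(C)c(Cl)c3)CC2)C(=O)Nc2ccccc21` in a functional assay on the whole organism (strain Wistar) with Rattus norvegicus as the target, with a stated time of 5 min; on this read-out higher numbers stand for an effect only at larger amounts of compound and lower numbers for an effect already at smaller amounts: > 20 mg/kg, a limit of the assay.
Compound 2 `CCC1(CCCCN2CCN(c3ccc(Cl)cc3)CC2)C(=O)Nc2cc(F)c(Cl)cc21`: "not determined" (no result reported).
Compound 3 `CCC1(CCCCN2CCN(c3ccc(F)c(Cl)c3)CC2)C(=O)Nc2ccccc21`: > 20 mg/kg, a limit of the assay.

Compound 3 stands at a limit of the assay, so no number is known for it. Compound 1 likewise ends at a limit. Compound 2 has no result at all. Going by the values given here, the one step among the measured compounds, a step that the two limits leave unreadable from compound 1 to compound 3, is a fluoro in place of methyl on an aromatic carbon, and its size cannot be read, the reason being (the limit of > 20 mg/kg in this assay, at which 2 of the 3 values shown sit).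

Compound 4 `CCC1(CCCCN2CCN(c3ccccc3Cl)CC2)C(=O)Nc2ccccc21` differs from compound 3 by 2-chlorophenyl in place of 3-chloro-4-fluorophenyl on an amine nitrogen in a ring. Among the compounds with values here, no measured step bears directly on this change; the only step present, the one from compound 1 to compound 3, is itself unreadable, so nothing in the data points to a shift in either direction beyond the scatter. The step is therefore estimated as a number no higher from compound 3 to compound 4 (the limit leaves the size open), and compound 4 is expected to behave as compound 3 does. Compound 4 is estimated at 20 mg/kg, with a range from 8 mg/kg to 40 mg/kg, and the result is expected most likely to come back again only as a limit of the assay.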

Compound 4, minimum effective dose: > 20 mg/kg
Compound 4: no number, only a limit (the forecaster's own chance of this, stated with the estimate: 70%); the middle value sits exactly at the limit.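

In this assay compound 4 gives > 20 mg/kg, a limit of the assay. Going by these compounds alone, no step among compound 1, compound 3 and compound 4 can be read, because all three end at that limit: the limit of > 20 mg/kg in this assay, at which 3 of the 4 values shown sit. The compounds shown leave open whether changing the group on the amine nitrogen in a ring alters the effect at all.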